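Swapping the Aryl Ether for a Direct Biaryl Link

The compounds below may be only part of what the source reports. "The series", "measured", "known", "first", "only" and "open" are said of these compounds alone.

Compound 2 `CN(C)c1cccc(Oc2ccc3c(NCCCNCc4ccco4)ccnc3c2)c1` is one of three close relatives measured in a physicochemical assay for solubility, with a stated time of 18 h, at pH 7.4; on this read-out higher numbers stand for higher solubility and lower numbers for lower solubility. In this assay compound 2 gives 14500 nM. Compound 1 `CC(C)(C)c1ccc(Oc2ccc3c(NCCCNCc4ccco4)ccnc3c2)cc1` gives 14500 nM and compound 3 `COc1ccc(F)cc1CNCCCNc1ccnc2cc(Oc3cccc(N(C)C)c3)ccc12` gives 14500 nM, so compound 2 stands level with both. The two known steps, no change at the digits printed from compound 1 to compound 2 (within the scatter) and no change at the digits printed from compound 2 to compound 3 (within the scatter), each replaced a single group without moving the read-out beyond the scatter. Compound 4 `COc1ccc(-c2ccc3c(NCCCNCc4ccco4)ccnc3c2)cc1` is not yet measured; it differs from compound 2 in this way: 4-methoxyphenyl in place of 3-(dimethylamino)phenoxy on an aromatic carbon. Neither known step removes the whole group that compound 4 loses, so the guidance is indirect; still, both stayed flat, and a flat step is expected here too: no change at the digits printed from compound 2 to compound 4 (within the scatter). Compound 4 is therefore expected to give 14500 nM, within 7000 nM to 29000 nM.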

Compound 4, solubility: 32000 nM
For compound 4 the middle estimate is 2.2-fold (0.34 log units) below the measured one; measured number above the stated range.
By their numbers in this assay, from the lowest: compounds 1, 2 and 3 (each within the scatter of the next); then compound 4.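

At this place on the core, the number in this assay does respond to a change: 4-methoxyphenyl in place of 3-(dimethylamino)phenoxy gives a 2.2-fold higher number from compound 2 to compound 4 (0.34 log units; beyond the scatter). Of the steps shown, this is the only one that goes beyond the scatter, and the only one that removes the oxygen link to the aromatic ring. No evidence here bears on why the number rose. This step swaps the link and the ring's substituent together, so their shares remain unseparated. A methoxyphenoxy group here would test the link alone, while a directly attached ring carrying a carboxylic acid would show how far the rise extends.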